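Pyrrolidine amide in place of an anilide: cytotoxicity outlook

This account rests on a few compounds, and the source may have more. Where it says the series, first, only, none or still open, it means among the compounds named here.

Measured in an ADME assay on HCT-116 cells (Homo sapiens) for cytotoxicity, read by MTT assay, with a stated time of 72 h; a higher number here means a weaker inhibitor, a lower number a stronger inhibitor:
- compound 1 `CCCCCN1C(=O)C/C(=C\c2cccc(C(=O)Nc3cccc(CC)c3)c2)C1=O` gives 75300 nM.
- compound 2 `COc1ccc(OC)c(NC(=O)c2cccc(/C=C3\CC(=O)N(c4ccccc4)C3=O)c2)c1` reaches only the limit > 100000 nM.
- compound 3 `O=C(Nc1ccc(Cl)cc1)c1cccc(/C=C2\CC(=O)N(Cc3ccccc3)C2=O)c1` reaches only the limit > 100000 nM.

Among the compounds with values here, compound 2 thus stands at the weak end of what has been measured: its result in this assay is a limit, not a number, and the limit of > 100000 nM in this assay, at which 2 of the 3 values shown sit, shows that it shares that limit with one other compound, while compound 1 is the only one with a numerical value. Compound 4 `O=C(c1cccc(/C=C2\CC(=O)N(c3ccccc3)C2=O)c1)N1CCCC1` differs from compound 2 in one place: pyrrolidin-1-yl in place of (2,5-dimethoxyphenyl)amino on a carbonyl carbon. Within the data shown here, no step between two measured compounds covers this change, so the direction cannot be read from the data. The three measured compounds all sit in the weak range, and nothing among them points to a large gain from the change. The step of a number no higher from compound 2 to compound 4 (the limit leaves the size open) is therefore expected to be small and likely within the scatter, with a fair chance that the assay again reports only a limit. Compound 4 is estimated at 100000 nM, between 40000 nM and 300000 nM.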

Compound 4, half-maximal inhibitory concentration: > 100000 nM
Compound 4: a limit, no number (the forecaster's own chance of this, stated with the estimate: 60%); the middle value lies on the limit itself.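

Compound 2 and compound 4 both end at a limit, not a number, so no step from one to the other can be read: the limit of > 100000 nM in this assay, at which 3 of the 4 values shown sit.

The compounds shown leave open whether pyrrolidin-1-yl in place of (2,5-dimethoxyphenyl)amino on a carbonyl carbon changes cytotoxicity at all.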